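Ester in place of allyl ether on a shared core

A few compounds are considered here, and "the series" means these few. Any claim that something is new, unique, unknown or untested is made for them only; others in the source may bear on it.

Compound 1 `C=CCOc1ccc2c(=O)c(-c3cc(OC)c(OC)cc3OC)coc2c1` gives 4750 nM in a functional assay on A-375 cells (Homo sapiens) for antiproliferative activity, read by MTT assay, with a stated time of 24 h (on this read-out higher numbers stand for weaker inhibition and lower numbers for stronger inhibition), the higher of the two numbers recorded. Compound 2 `COc1ccc2c(=O)c(-c3cc(OC)c(OC)cc3OC)coc2c1` gives 2640 nM in this assay, and the step of a 1.8-fold lower number from compound 1 to compound 2 (0.26 log units; within the scatter) shows that hydrogen in place of allyl on the oxygen changes little. Compound 3 `COc1cccc(C(=O)Oc2ccc3c(=O)c(-c4cc(OC)c(OC)cc4OC)coc3c2)c1` carries (3-methoxyphenyl)carbonyl in place of allyl on an oxygen on an aromatic ring. Within the data shown here, no measured step covers this change directly; the one step available suggests the oxygen substituent matters little, so compound 3 is expected to differ from compound 1 by a 1.2-fold lower number from compound 1 to compound 3 (0.07 log units; within the scatter), within the scatter. Compound 3 is therefore estimated at 4000 nM, with a range from 1500 nM to 12000 nM.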

Compound 3, half-maximal inhibitory concentration: > 10000 nM
Compound 3 was reported as a limit; the forecaster's own chance of this, stated with the estimate: 5%; middle value at least 2.5-fold (0.39 log units) away from the limit.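

The oxygen on the aromatic ring is not indifferent to its substituent: (3-methoxyphenyl)carbonyl in place of allyl gives an at least 2.1-fold higher number from compound 1 to compound 3 (0.32 log units; beyond the scatter) in this assay and in place of methyl gives an at least 3.7-fold higher number from compound 2 to compound 3 (0.57 log units; beyond the scatter) while allyl and methyl stayed within the scatter of each other. Compound 3 is reported only as a limit, so both steps are lower bounds: the limit of > 10000 nM in this assay, at which 1 of the 3 values shown sits.

From the compounds shown here alone, whether the weaker inhibition follows from the carbonyl link or from the added aromatic ring stays open. An acetyl ester or a benzyl ether on this oxygen would separate the two.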